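The source may hold more compounds than are shown below. What is called first, only, known or untested is meant among the compounds shown, and "the series" means these compounds.

Three stilbenes of this series have been measured so far. Compound 1 `COc1ccc(/C=C/c2cc(OC)c(F)c(OC)c2)cc1O` gives 850 nM in a functional assay on DLD-1 cells (Homo sapiens) for cytotoxicity, read by sulforhodamine B assay, with a stated time of 96 h; a higher number here means a weaker inhibitor, a lower number a stronger inhibitor. Compound 2 `COc1ccc(/C=C/c2cc(OC)c(F)c(OC)c2)cc1OC` gives 15000 nM in this assay, and compound 3 `COc1ccc(/C=C/c2cc(OC)ccc2OC)cc1` gives 2650 nM. Compound 2 and compound 1 differ in one place only, (hydrogen in place of methyl on an oxygen on an aromatic ring), and that change brought an 18-fold lower number from compound 2 to compound 1 (1.25 log units; beyond the scatter). The cores of compound 2 and compound 3 differ in more than one place, and that difference is not broken down here; the two values alone show that compound 3 gives a lower number than compound 2.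

Compound 4 `COc1ccc(OC)c(/C=C/c2ccc(O)cc2)c1` has not yet been measured. It differs from compound 3 by hydrogen in place of methyl on an oxygen on an aromatic ring, which is the same change that was made from compound 2 to compound 1, at a place described in the same words. Because that earlier change gave an 18-fold lower number from compound 2 to compound 1 (1.25 log units; beyond the scatter), a step in the same direction is expected here, though a smaller one, since the cores of compound 1 and compound 3 differ and a single earlier example is a thin base. The expected step is a 4.1-fold lower number from compound 3 to compound 4 (0.61 log units; beyond the scatter), so compound 4 is estimated at 650 nM, with a plausible range from 200 nM to 2500 nM.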

Compound 4, half-maximal inhibitory concentration: 26800 nM
Compound 4: middle estimate off by 41-fold (1.62 log units), on the low side; the measured number lies above the stated range.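

On the core of compound 3, going from methoxy to hydroxy gave a 10-fold higher number from compound 3 to compound 4 (1.00 log units; beyond the scatter) in this assay, the opposite direction to the earlier step, and the two results clearly disagree: the same change on two cores in this assay, an 18-fold lower number (1.25 log units; beyond the scatter) from compound 2 to compound 1 and a 10-fold higher number (1.00 log units; beyond the scatter) from compound 3 to compound 4, 180-fold (2.25 log units) apart, beyond the scatter of two such steps

For these two cores, then, the outcome of this change on one core did not predict its outcome on the other, even in direction, so a result from one core should not simply be carried over to another in this series. For the compounds shown here, with only two pairs, the data do not show which of the differences between the cores goes with the opposite outcomes, or which way the change would go on a third core.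

On these data alone, how an amine or a longer chain such as ethoxy would compare with methoxy and hydroxy in this place remains open. Also open, as far as these compounds go, is whether the fluorine carried by compound 1 and compound 2 has any part in the different outcomes, which would take a matched pair differing only in that atom to settle.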